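Series notes: amine terminus change, compound 2 to compound 3

This account rests on a few compounds, and the source may have more. Where it says the series, first, only, none or still open, it means among the compounds named here.

Of the compounds shown here, two have been measured in a functional assay on MCF7 cells (Homo sapiens) for antiproliferative activity, read by MTT assay, with a stated time of 72 h; a lower number here means a stronger inhibitor, a higher number a weaker inhibitor. Compound 2 `CCN1CCN(CCCOc2cc3ncnc(Nc4ccc(C#N)cc4)c3cc2OC)CC1` gives 29900 nM. The only other measured compound, compound 1 `COc1cc2c(Nc3ccc(C#N)cc3)ncnc2cc1OCCCN1CCC(N2CCCCC2)CC1`, gives 19600 nM in this assay, and the step of a 1.5-fold higher number from compound 1 to compound 2 (0.18 log units; within the scatter) lies within the scatter, so the two sit together on the numbers shown. Compound 3 `COc1cc2c(Nc3ccc(C#N)cc3)ncnc2cc1OCCCN1CCN(c2ccncc2)CC1` is not yet measured; its difference from compound 2 is pyridin-4-yl in place of ethyl on an amine nitrogen in a ring. Among the compounds with values here, the one measured step touches the same end of the chain, the amine reached three bonds from the aromatic oxygen, and that step, a 1.5-fold higher number from compound 1 to compound 2 (0.18 log units; within the scatter), was within the scatter. Within the data shown here, no measured step covers an aromatic group on that amine nitrogen. On that basis compound 3 is expected to land near compound 2, with the step of a 1.1-fold lower number from compound 2 to compound 3 (0.04 log units; within the scatter) estimated as no more than the scatter. Compound 3 is estimated at 27000 nM, within 9000 nM to 80000 nM.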

Compound 3, half-maximal inhibitory concentration: 22900 nM
For compound 3 the middle estimate is 1.2-fold (0.07 log units) above the measured one; low and high end bracket the measured number.
By their numbers in this assay, from the lowest: compounds 1, 3 and 2 (each within the scatter of the next).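

On the amine nitrogen in the ring, only compound 3 carries an aromatic group, and pyridin-4-yl in place of ethyl leaves the number in this assay within the scatter (a 1.3-fold lower number from compound 2 to compound 3 (0.12 log units; within the scatter)). The exchange of the whole terminus, 4-(pyridin-4-yl)piperazin-1-yl in place of 4-(piperidin-1-yl)piperidin-1-yl, is also within the scatter (a 1.2-fold higher number from compound 1 to compound 3 (0.07 log units; within the scatter)), so the three termini shown sit together on these numbers. Nothing at hand bears on why this position tolerates the change.

As far as these compounds go, whether a carboxylic acid or a benzyl group on that nitrogen, or a morpholine as the whole terminus, would move the number beyond the scatter stays open. So does the effect of a shorter or longer chain between the oxygen and the amine.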